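Working notes: from compound 3 to compound 4

A few compounds are considered here, and "the series" means these few. Any claim that something is new, unique, unknown or untested is made for them only; others in the source may bear on it.

In an in vitro assay on BL21-DE3 cells for displacement of a labelled ligand from thyroid hormone receptor beta (Homo sapiens), read by fluorescence polarization (on this read-out lower numbers stand for stronger inhibition and higher numbers for weaker inhibition), compound 3 `C#CC(=O)Nc1ccc(CCCCCC)cc1` gives 35100 nM. Compound 1 `CCCCCCc1ccc(C(=O)/C=C\C(=O)O)cc1` gives 17700 nM in this assay, and the two numbers lie within the scatter of each other, compound 3 holding the higher of the two numbers measured. Compound 2 `C/C=C/C(=O)Nc1ccc(CCCCCC)cc1` gives only a limit in this assay, > 100000 nM. Among the measured compounds shown here, the one step measured so far is an at least 2.8-fold lower number from compound 2 to compound 3 (0.45 log units; beyond the scatter), whose size is bounded by the limit of > 100000 nM in this assay, at which 1 of the 3 values shown sits.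

Compound 4 `CCCCCCc1ccc(C(=O)CCBr)cc1` differs from compound 3 by (2-bromoethyl)carbonyl in place of (ethynylcarbonyl)amino on an aromatic carbon. For the measured compounds named here, no measured step covers this exchange. The step from compound 2 to compound 3 alters only the group on the carbonyl carbon and keeps the amide, whereas compound 4 loses the amide and carries its carbonyl directly on the ring, as compound 1 does. Since compound 1 and compound 3 sit within the scatter of each other in this assay, no step beyond the scatter is expected in either direction. The expected step is a 1.4-fold lower number from compound 3 to compound 4 (0.15 log units; within the scatter). Compound 4 is therefore estimated at 25000 nM, between 7000 nM and 90000 nM, with some chance that this assay returns only a limit.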

Compound 4, half-maximal inhibitory concentration: 3000 nM
Estimate against measurement, compound 4: 8.3-fold (0.92 log units) above; measured number below the stated range.
By their numbers in this assay, from the lowest: compound 4; then compounds 1 and 3 (each within the scatter of the next). At a limit, above all of these: compound 2.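

In this assay, among the compounds shown here, (2-bromoethyl)carbonyl in place of (ethynylcarbonyl)amino, on an aromatic carbon para to a group of 6 heavy atoms, gives a 12-fold lower number from compound 3 to compound 4 (1.07 log units; beyond the scatter), the first large step between measured numbers. Compound 1 also carries a carbonyl directly on the ring, yet 2-bromoethyl in place of 2-carboxyethenyl on that carbonyl carbon gives a 5.9-fold lower number from compound 1 to compound 4 (0.77 log units; beyond the scatter), so losing the amide is not enough to account for the lower number of compound 4, and the group on the carbonyl carbon makes a difference beyond the scatter. Compound 2 is a limit and not a number, so an at least 33-fold lower number from compound 2 to compound 4 (1.52 log units; beyond the scatter) gives only a lower bound on the size of that step: the limit of > 100000 nM in this assay, at which 1 of the 4 values shown sits.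

On these data alone, whether the bromine itself matters stays open, and a 2-chloroethyl or a plain ethyl group on the same carbonyl carbon would separate its part from that of the saturated chain. Also open, as far as these compounds go, is how far the number of compound 4 depends on the group of 6 heavy atoms, for which a shorter chain or a longer chain would be the test.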